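A few compounds are considered here, and "the series" means these few. Any claim that something is new, unique, unknown or untested is made for them only; others in the source may bear on it.

Three compounds have been measured so far in a functional assay on A549 cells (Homo sapiens) for inhibition, read by MTT assay, with a stated time of 72 h (on this read-out higher numbers stand for weaker inhibition and lower numbers for stronger inhibition), as follows:

- compound 1 (`CC(C)(C)n1cc2c(n1)C(=O)CC1(CCN(C(=O)c3cc(-c4ccccc4)nc4ccccc34)CC1)O2`) gives 1940 nM
- compound 2 (`COc1ccc(-c2cc(C(=O)N3CCC4(CC3)CC(=O)c3nn(C(C)(C)C)cc3O4)c3ccccc3n2)cc1OC`) gives 2030 nM
- compound 3 (`CC(C)(C)n1cc2c(n1)C(=O)CC1(CCN(C(=O)c3cc(-c4ccncc4)nc4ccccc34)CC1)O2`) gives 550 nM

Compound 3 has the lowest number of the three, and its distance from each of the others lies beyond the scatter. Compound 1 and compound 2 stand within the scatter of each other (a 1.0-fold higher number from compound 1 to compound 2 (0.02 log units; within the scatter)).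

The unmeasured compound 4 (`COc1cc(C(=O)N2CCC3(CC2)CC(=O)c2nn(C(C)(C)C)cc2O3)c2ccccc2n1`) has methoxy in place of pyridin-4-yl on an aromatic carbon, next to the ring nitrogen (methoxy in place of pyridin-4-yl on an aromatic carbon). For the measured compounds named here, all the measured steps change the group on this same carbon, so they are the ones that bear on the question. None of them places a group without a ring there, which makes the guidance indirect.

Both steps that arrive at pyridin-4-yl are modest (a 3.5-fold lower number from compound 1 to compound 3 (0.55 log units; beyond the scatter)) and (a 3.7-fold lower number from compound 2 to compound 3 (0.57 log units; beyond the scatter)). Read backwards, they suggest that compounds without pyridin-4-yl on this carbon may sit higher by a similar amount. A modest rise is therefore expected, with wide uncertainty (a 3.5-fold higher number from compound 3 to compound 4 (0.54 log units; beyond the scatter)). Compound 4 is estimated at 1900 nM on this read-out, with an expected range from 600 nM to 6000 nM in this estimate.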

Compound 4, half-maximal inhibitory concentration: > 10000 nM
Compound 4 ended at the assay's limit; the forecaster's own chance of this, stated with the estimate: 7%; at least 5.2-fold (0.72 log units) between middle value and limit.
By their numbers in this assay, from the lowest: compound 3; then compounds 1 and 2 (each within the scatter of the next). At a limit, above all of these: compound 4.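

In this assay compound 4 gives > 10000 nM, which is a limit of the assay and not a number: the limit of > 10000 nM in this assay, at which 1 of the 4 values shown sits. For the compounds shown here, until this result, the group on this aromatic carbon had always carried a ring, and exchanging one such group for another had moved the number by modest steps at most, whereas methoxy in place of pyridin-4-yl gives a large step (an at least 18-fold higher number from compound 3 to compound 4 (1.25 log units; beyond the scatter)). Compound 4 also does not simply return to the level of the compounds with phenyl (an at least 5.1-fold higher number from compound 1 to compound 4 (0.71 log units; beyond the scatter)) or 3,4-dimethoxyphenyl (an at least 4.9-fold higher number from compound 2 to compound 4 (0.69 log units; beyond the scatter)), so the earlier gain seen with pyridin-4-yl does not account for the whole loss, and at this carbon a small group without a ring fares worse than all three ring-bearing groups shown.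

With a single group without a ring, the compounds shown cannot separate the loss of the ring from an effect of methoxy itself, and the limit leaves the true size of all three steps unknown. Going by these compounds, whether an amine such as dimethylamino, a longer chain such as butoxy, or a saturated ring such as morpholine would hold the number nearer that of compound 3 stays open.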